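Propargyl for methyl on the aromatic amine of compound 1

A few compounds are considered here, and "the series" means these few. Any claim that something is new, unique, unknown or untested is made for them only; others in the source may bear on it.

Among the compounds with values here, compound 1 `Cc1nc(O)c2cc(CN(C)c3ccc(C(=O)N[C@@H](CCC(=O)O)C(=O)N(C)[C@@H](CCC(=O)O)C(=O)O)c(F)c3)ccc2n1` is one of two compounds measured in a functional assay for inhibition, with Mus musculus as the target; a higher number here means a weaker inhibitor, a lower number a stronger inhibitor; in this assay compound 1 gives 5100 nM, the lowest of the two numbers. Within the data shown here, its only neighbour, compound 2 `Cc1nc(O)c2cc(CN(C)c3ccc(C(=O)N[C@@H](CCC(=O)O)C(=O)N(C)[C@@H](CCC(=O)O)C(=O)O)c(F)c3)c(C)cc2n1`, gives 5600 nM, and the single step recorded, a 1.1-fold higher number from compound 1 to compound 2 (0.04 log units; within the scatter), involves a methyl in place of hydrogen on an aromatic carbon. Compound 3 `C#CCN(Cc1ccc2nc(C)nc(O)c2c1)c1ccc(C(=O)N[C@@H](CCC(=O)O)C(=O)N(C)[C@@H](CCC(=O)O)C(=O)O)c(F)c1` differs from compound 1 at another place: ethynyl in place of hydrogen on a saturated chain carbon bound to a nitrogen on an aromatic ring. Among the measured compounds shown here, no measured step touches this saturated chain carbon, so the step from compound 1 to compound 2 bears on it only by showing that a small change elsewhere left the number within the scatter. On this basis compound 3 is expected to give about 3000 nM, in the range 1000 nM to 12000 nM, which would mean a step of a 1.7-fold lower number from compound 1 to compound 3 (0.23 log units; within the scatter) from compound 1 and a modestly lower number.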

Compound 3, half-maximal inhibitory concentration: 1800 nM
Compound 3: the middle estimate sits 1.7-fold (0.22 log units) above what was measured; low and high end bracket the measured number.
By their numbers in this assay, from the lowest: compound 3; then compounds 1 and 2 (each within the scatter of the next).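

Compounds 1 and 2 differ only by a methyl on an aromatic carbon, a step within the scatter, and so said nothing about the saturated chain carbon bound to a nitrogen on an aromatic ring. In this assay, methyl to propargyl at this place gives a 2.8-fold lower number from compound 1 to compound 3 (0.45 log units; beyond the scatter) and is the first change shown to move the number beyond the scatter, so this position tolerates the added ethynyl and responds to it with a stronger inhibitor. Nothing given here bears on what lies behind this step.

The compounds shown leave open whether the triple bond matters or only the longer chain, which a propyl or an allyl group in place of the propargyl would separate. They also leave open whether the propargyl and the aromatic methyl of compound 2 would combine.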